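Amide Side-Chain Exchange on a Dodecylamine Scaffold

A few compounds are considered here, and "the series" means these few. Any claim that something is new, unique, unknown or untested is made for them only; others in the source may bear on it.

Compound 1 `CCCCCCCCCCCCNCCN`: 1000 nM
Compound 2 `CCCCCCCCCCCCNC(=O)C(N)CN`: 2510 nM

Of the compounds shown here, two have been measured in a functional assay on HL-60 cells (Homo sapiens) for activation; on this read-out lower numbers stand for an effect already at smaller amounts and higher numbers for an effect only at larger amounts of compound. Compound 1 gives 1000 nM, and compound 2 gives 2510 nM. Going by the values given here, the only measured step is a 2.5-fold higher number from compound 1 to compound 2 (0.40 log units; beyond the scatter), which places compound 2 as the higher of the two numbers in this assay.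

Compound 3 `CCCCCCCCCCCCNC(=O)[C@@H](N)CCC(N)=O` has not yet been measured. It differs from compound 2 by 1-amino-3-carbamoylpropyl in place of 1,2-diaminoethyl on a carbonyl carbon. Among the compounds with values here, the one measured step concerns a change on an amine nitrogen rather than on a carbonyl carbon, so it bears on the present change only loosely; it does show that exchanging the polar side chain on this scaffold moved the number by a modest amount. The change from compound 2 to compound 3 keeps the same counts of donors and acceptors but replaces one amino group with a carbamoyl group and lengthens the side chain. On that basis a modest step upward in this assay is expected, a 1.6-fold higher number from compound 2 to compound 3 (0.20 log units; within the scatter). Compound 3 is therefore estimated at 4000 nM, within a range from 1500 nM to 12000 nM.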

Compound 3, half-maximal effective concentration: 7940 nM
Compound 3: middle estimate off by 2.0-fold (0.30 log units), on the low side; the measured number falls inside the stated range.
By their numbers in this assay, from the lowest: compound 1; then compound 2; then compound 3.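

In this assay, the exchange on a carbonyl carbon whose other neighbour is an amide-type nitrogen gives a 3.2-fold higher number from compound 2 to compound 3 (0.50 log units; beyond the scatter) and lies beyond the scatter, showing that the number still moves when the carbonyl stays in place and only the group on it changes. The earlier step had introduced that carbonyl on the amine nitrogen, so it could not show this. The leaving 1,2-diaminoethyl and the entering 1-amino-3-carbamoylpropyl have the same hydrogen-bond donor and acceptor counts and no net charge, so the step comes with no change in those counts, only with more heavy atoms, a double bond and a defined stereocentre, and nothing measured here accounts for it.

On these data alone, whether the higher number goes with the carbamoyl group, the longer chain or the defined stereocentre stays open, as all three enter together in this one step. The compounds shown also leave open how a carboxylic acid or an amine at the end of the same side chain would read in this assay on this scaffold.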